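This account rests on a few compounds, and the source may have more. Where it says the series, first, only, none or still open, it means among the compounds named here.

Of the compounds shown here, three of a shared core have been measured in a functional assay on CCRF-SB cells (Homo sapiens) for cytotoxicity, read by MTT assay, with a stated time of 96 h; a higher number here means that more compound is needed for the effect, a lower number that less compound is needed. Compound 1 `O=C(/C(=C\c1c(-c2ccccc2)[nH]c2ccccc12)C(=O)C(F)(F)F)c1ccco1` gives 1800 nM, compound 2 `N#C/C(=C\c1c(-c2ccccc2)[nH]c2ccccc12)C(=O)c1cccs1` gives 600 nM, and compound 3 `CC(=O)/C(=C/c1c(-c2ccccc2)[nH]c2ccccc12)C(=O)c1ccccc1` gives 11000 nM. Compound 2 has the lowest number of the three: compound 1 sits beyond the scatter above it, and compound 3 lies further still.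

Compound 4 `N#C/C(=C\c1c(-c2ccccc2)[nH]c2ccccc12)C(=O)c1ccc(Cl)cc1` has not yet been measured in this assay. It differs from compound 2 in one place: 4-chlorophenyl in place of thiophen-2-yl on a carbonyl carbon. Going by the values given here, no measured pair shows this exact change, so its size can only be guessed. The step is expected to be small, toward a somewhat higher number, roughly a 1.5-fold higher number from compound 2 to compound 4 (0.18 log units; within the scatter). Compound 4 is therefore estimated to give about 900 nM, with a likely range from 350 nM to 2500 nM.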

Compound 4, half-maximal effective concentration: 600 nM
Beside the measured number, compound 4's estimate is 1.5-fold (0.18 log units) above it; the range from low to high includes it.
By their numbers in this assay, from the lowest: compounds 2 and 4 (each within the scatter of the next); then compound 1; then compound 3.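

In this assay, going by these compounds alone, the exchange of thiophen-2-yl for 4-chlorophenyl on this carbonyl carbon gives no change at the digits printed from compound 2 to compound 4 (within the scatter) and so provides the first comparison that differs in one place. With the nitrile kept, a six-membered aromatic ring of carbon only and a five-membered aromatic ring with one hetero atom cannot be told apart here. No measurement offers an explanation for this. As far as these compounds go, it remains open whether a ring carrying an amine or a carboxylic acid, or a longer chain in place of the ring, would give a similar number.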